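Chloromethyl extension repeated on the imidazolyl analogue

The compounds below may be only part of what the source reports. "The series", "measured", "known", "first", "only" and "open" are said of these compounds alone.

Measured so far:
compound 1, `CC(=O)N1N=C(c2ccc(N3CCN(C)CC3)cc2)CC1c1ccc(N(C)C)cc1`: -0.8%
compound 2, `CN1CCN(c2ccc(C3=NN(C(=O)CCCl)C(c4ccc(N(C)C)cc4)C3)cc2)CC1`: 1.7%
compound 3, `CC(=O)N1N=C(c2ccc(-n3ccnc3)cc2)CC1c1ccc(N(C)C)cc1`: -9.7%

All three were tested in a functional assay on HCC1806 cells (Homo sapiens) for inhibition, read by sulforhodamine B assay, tested at 10 uM; a higher number here means more inhibition at the concentration tested (going by the name of the read-out), a lower number less inhibition. The numbers lie close together, and none of the three shows appreciable inhibition at the concentration used. Compound 1 and compound 2 differ only in chloromethyl in place of hydrogen on a saturated chain carbon bound to a carbonyl carbon, and the step of a number 2.5 percentage points higher from compound 1 to compound 2 (within the scatter). Compound 3 carries a different core: against compound 1 the difference is 1H-imidazol-1-yl in place of 4-methylpiperazin-1-yl on an aromatic carbon, and the step of a number 8.9 percentage points lower from compound 1 to compound 3 (within the scatter). Of the three numbers, that of compound 3 is the lowest, but its gap to compound 1 is within the scatter, so nothing is made of it; only the gap to compound 2 is beyond the scatter.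

Compound 4, `CN(C)c1ccc(C2CC(c3ccc(-n4ccnc4)cc3)=NN2C(=O)CCCl)cc1`, has not been measured. It differs from compound 3 by chloromethyl in place of hydrogen on a saturated chain carbon bound to a carbonyl carbon, the same change as between compound 1 and compound 2, at the same place. On the core of compound 1 that change gave a number 2.5 percentage points higher from compound 1 to compound 2 (within the scatter). On the core of compound 3 a step of similar size is expected, a number 2.7 percentage points higher from compound 3 to compound 4 (within the scatter), because a number 2.5 percentage points higher from compound 1 to compound 2 (within the scatter) was within the scatter. For compound 4 the expected read-out in this assay is -7%, between -20% and 6%.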

Compound 4, a percentage reported as inhibition, at one concentration (the size of the read-out at that concentration, not a potency): -5.2%
For compound 4 the middle estimate is 1.8 percentage points below the measured one; low and high end bracket the measured number.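

In this assay, the chloromethyl change on the core of compound 3 gives a number 4.5 percentage points higher from compound 3 to compound 4 (within the scatter), and the comparison with the core of compound 1 shows no difference between the two cores: the same change on two cores in this assay, a number 2.5 percentage points higher (within the scatter) from compound 1 to compound 2 and a number 4.5 percentage points higher (within the scatter) from compound 3 to compound 4, 2 percentage points apart, within the scatter of two such steps. The exchange of 4-methylpiperazin-1-yl for 1H-imidazol-1-yl, read with the chloromethyl group in place, gives a number 6.9 percentage points lower from compound 2 to compound 4 (within the scatter), and it too matches its earlier counterpart: the same change on two cores in this assay, a number 8.9 percentage points lower (within the scatter) from compound 1 to compound 3 and a number 6.9 percentage points lower (within the scatter) from compound 2 to compound 4, 2 percentage points apart, within the scatter of two such steps. This shows only that, on these two cores, the chloromethyl change leaves the read-out within the scatter; with no appreciable inhibition among the four compounds, it does not show a real effect that carries from core to core, nor how the change would behave on a core with measurable inhibition.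

Still open, on these data alone, is whether another group in place of the 2-chloroethyl, such as a longer chloroalkyl chain or an amine, would move the read-out on either core. Also open, as far as these compounds go, is whether a carboxylic acid on the aromatic carbon that bears the 1H-imidazol-1-yl would do so.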